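The compounds below may be only part of what the source reports. "The series", "measured", "known", "first", "only" and "open" are said of these compounds alone.

Measured compounds:
compound 1, `CC[C@H](C)[C@H](N)CN(C(=O)[C@@H]1C[C@H]1c1ccc(Cl)cc1)c1ccc(-c2ccccc2)cc1`, in a functional assay for agonist activity at G protein-coupled receptor 88 (Homo sapiens), read by HTRF and cAMP accumulation (on this read-out lower numbers stand for an effect already at smaller amounts and higher numbers for an effect only at larger amounts of compound), compound 1 gives 4300 nM.
compound 2, `CC[C@H](C)[C@H](N)CN(C(=O)[C@@H]1C[C@H]1c1ccccc1)c1ccc(-c2ccc(C(F)(F)F)cc2)cc1`, in this assay compound 2 gives 340 nM.

For the measured compounds named here, of the two numbers measured so far, compound 2 holds the lower one, and the gap from compound 1 to compound 2 lies beyond the usual scatter of this kind of measurement. Compound 1 and compound 2 differ in two places at once, so nothing can be said about which of those places carries the gap; only the two values themselves are known.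

Compound 3, `CC[C@H](C)[C@H](N)CN(C(=O)[C@@H]1C[C@H]1c1ccccc1)c1ccc(-c2ccc(CNC)cc2)cc1`, has not been measured yet. It differs from compound 2 in one place: (methylamino)methyl in place of trifluoromethyl on an aromatic carbon. Going by the values given here, no pair of measured compounds shows this change, or any change at this position, on its own, so no measured step can guide the expectation. The direction and size of the step from compound 2 to compound 3 are therefore uncertain; a moderate move toward a higher number is expected, with wide limits, as a 2.6-fold higher number from compound 2 to compound 3 (0.42 log units; beyond the scatter). For compound 3 in this assay the estimate is 900 nM, within a range from 150 nM to 5000 nM.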

Compound 3, half-maximal effective concentration: 6400 nM
Compound 3: the middle estimate sits 7.1-fold (0.85 log units) below what was measured, and the stated range ends below it.
By their numbers in this assay, from the lowest: compound 2; then compounds 1 and 3 (each within the scatter of the next).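

Replacing trifluoromethyl with (methylamino)methyl on the aromatic carbon gives, in this assay, a 19-fold higher number from compound 2 to compound 3 (1.27 log units; beyond the scatter), a large step. For the compounds shown here, this is the first comparison that changes only one place, which compounds 1 and 2 could not offer, and it shows that this position alone can shift the number substantially. Here, the change removes a group with no hydrogen-bond donors or acceptors and brings in one with a hydrogen-bond donor and a hydrogen-bond acceptor, and it moves the number upward, so that more compound is needed for the effect. No measurement shown here bears on the cause of this step.

With a single pair, the step cannot be assigned to the loss of the trifluoromethyl group or to the arrival of the (methylamino)methyl group. On these data alone, a plain methyl group, a methoxymethyl group or a dimethylaminomethyl group at this position would help separate these two possibilities, and it remains open whether the value for any of them would lie closer to that of compound 2 or compound 3.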